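Pyridyl isomer swap on the biaryl methylene series

This account rests on a few compounds, and the source may have more. Where it says the series, first, only, none or still open, it means among the compounds named here.

Measured so far:
compound 1 `c1ccc2c(-c3ccc(C(C4CC4)n4ccnc4)cn3)cccc2c1`: 220 nM
compound 2 `c1ccc(-c2ccc(Cc3cccnc3)cn2)cc1`: 322 nM

In an in vitro assay on V79MZh cells for inhibition of cytochrome P450 11B2, mitochondrial (Homo sapiens) (on this read-out lower numbers stand for stronger inhibition and higher numbers for weaker inhibition), compound 1 gives 220 nM and compound 2 gives 322 nM. Compound 2 holds the higher of the two numbers, yet its gap to compound 1 lies within the scatter, so no order between the two is read. Among the compounds with values here, the two structures differ in more than one place, and no single-point step between measured compounds exists in this set.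

Compound 3 `c1ccc(-c2ccc(Cc3ccncc3)cn2)cc1` is not yet measured. It shares all atoms with compound 2 and differs from it only by pyridin-4-yl in place of pyridin-3-yl on a saturated chain carbon bound to an aromatic carbon. Within the data shown here, no measured pair isolates this change, so its step size is unknown. The expectation for this assay is a step of a 1.4-fold higher number from compound 2 to compound 3 (0.15 log units; within the scatter) of modest size, most likely toward a somewhat higher number, though a result within the scatter of compound 2 is also plausible. For compound 3 the estimate in this assay is 450 nM, with an expected range of 150 nM to 1400 nM.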

Compound 3, half-maximal inhibitory concentration: 621 nM
Compound 3: middle estimate off by 1.4-fold (0.14 log units), on the low side; the range from low to high includes it.
By their numbers in this assay, from the lowest: compounds 1, 2 and 3 (each within the scatter of the next, the first and the last beyond it).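

In this assay, within the data shown here, pyridin-4-yl in place of pyridin-3-yl on a saturated chain carbon bound to an aromatic carbon gives a 1.9-fold higher number from compound 2 to compound 3 (0.29 log units; within the scatter), the first step that isolates a single place. With the same atoms joined differently, this isomer swap leaves compound 2 and compound 3 unseparated by this read-out, so no preference between pyridin-3-yl and pyridin-4-yl can be read at this place, a question that the comparison of compound 1 with compound 2 could not address. No supporting data bear on why the two isomers read as they do.

Still open, going by these compounds, is whether pyridin-2-yl or pyrimidin-5-yl on the same saturated chain carbon would stay within the scatter of compound 2 or move clearly beyond it. Among these compounds, also open is whether the same swap would read alike on the core of compound 1, where the saturated chain carbon also carries a cyclopropyl group and an imidazole ring takes the place of the pyridine, so the single step from compound 2 to compound 3 cannot be carried across to that core.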